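This account rests on a few compounds, and the source may have more. Where it says the series, first, only, none or still open, it means among the compounds named here.

Working notes on the step to compound 4 `Cc1c(C(O)(C2CC2)C(F)(F)F)ccc(C#N)c1C(F)(F)F`. In a physicochemical assay for solubility, read by chemiluminescence, in phosphate buffer, measured as kinetic solubility, with a stated time of 1 h, at pH 7.4 (on this read-out lower numbers stand for lower solubility and higher numbers for higher solubility), compound 3 `Cc1c(C(O)(c2cocn2)C(F)(F)F)ccc(C#N)c1C(F)(F)F` gives > 400000 nM, which is a limit and not a number. The other two measured values are limits as well. Compound 1 `N#Cc1ccc(C(O)(c2cocn2)C(F)(F)F)cc1C(F)(F)F` gives > 700000 nM, also a limit. Compound 2 `N#Cc1ccc(C(O)(C2CC2)C(F)(F)F)cc1Cl`, which already carries cyclopropyl at the place in question, gives > 400000 nM, again a limit. Overall, the series shows (the limit of > 400000 nM in this assay, at which 2 of the 3 values shown sit), and (the limit of > 700000 nM in this assay, at which 1 of the 3 values shown sits).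

The change is cyclopropyl in place of 1,3-oxazol-4-yl on a saturated chain carbon bound to an aromatic carbon, an oxygen on a saturated carbon and a saturated chain carbon.

For the measured compounds named here, the only measured step is a step that the two limits leave unreadable from compound 1 to compound 3, and it is a different change, methyl in place of hydrogen on an aromatic carbon, so it offers no size to carry over. No step beyond the scatter is expected in this assay, and no direction can be given. Going by the values given here, the one guide to cyclopropyl is compound 2 at > 400000 nM, itself a limit. The estimated step is a number no higher from compound 3 to compound 4 (the limit leaves the size open). Another limit is the likeliest report. For compound 4 the expected value is 400000 nM, with an estimated range of 150000 nM to 700000 nM.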

Compound 4, solubility: 245000 nM
Beside the measured number, compound 4's estimate is 1.6-fold (0.21 log units) above it; the measured number falls inside the stated range.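

In this assay, for the compounds shown here, compound 4 is the only compound of the series that reads as a number and not as a limit, which gives this place on the saturated chain carbon its first readable bound. Cyclopropyl in place of 1,3-oxazol-4-yl gives an at least 1.6-fold lower number from compound 3 to compound 4 (0.21 log units; that floor lies within the scatter), and with a limit on one side only this floor is known, so the true step may be larger or may stay within the usual scatter. The other step in the series cannot be read, and the remaining values shown are limits: the limit of > 400000 nM in this assay, at which 2 of the 4 values shown sit.

The compounds shown leave open how large the step from 1,3-oxazol-4-yl to cyclopropyl really is, and whether the same change gives a step of similar size on the core of compound 1. They also leave open how an amine, a carboxylic acid or a longer chain on this saturated chain carbon would read in this assay, since only cyclopropyl and 1,3-oxazol-4-yl appear at this place.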